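Smaller Terminal Ring on the Chain of Compound 2

This account rests on a few compounds, and the source may have more. Where it says the series, first, only, none or still open, it means among the compounds named here.

Measured compounds in a functional assay on HeLa cells (Homo sapiens) for cytotoxicity, read by WST assay, with a stated time of 48 h; a lower number here means a stronger inhibitor, a higher number a weaker inhibitor:
Compound 1, `COc1ccc(/C=C/C[C@@H]2C[C@@H]([C@@H](O)c3ccc(OC)c(OC)c3)CO[C@H]2c2ccc(OC)c(OC)c2)cc1OC`, gives 30600 nM.
Compound 2, `O[C@@H](c1ccccc1)[C@H]1CO[C@H](c2ccccc2)[C@@H](C/C=C/C2CCCCC2)C1`, gives 6440 nM.
Compound 3, `COc1ccc([C@H](O)[C@H]2CO[C@@H](c3ccc(OC)c(OC)c3)[C@H](C/C=C/c3ccccc3)C2)cc1OC`, gives 16100 nM.

Compound 2 stands at the lowest number of the three, with compound 3 nearest and compound 1 furthest, both gaps beyond the scatter. Compound 4, `O[C@@H](c1ccccc1)[C@H]1CO[C@H](c2ccccc2)[C@@H](C/C=C/C2CCCC2)C1`, has not yet been measured. It differs from compound 2 in one place: cyclopentyl in place of cyclohexyl on a double-bonded chain carbon bound to a double-bonded chain carbon. The only measured step among these compounds, a 1.9-fold lower number from compound 1 to compound 3 (0.28 log units; within the scatter), swaps one aromatic group for another at a double-bonded chain carbon bound to a double-bonded chain carbon and lands within the scatter. Within the data shown here, no measured step exchanges one non-aromatic ring for another, so nothing bears directly on the change from a six-membered to a five-membered ring of carbon only. Among the measured compounds shown here, the one step at this part of the chain was small. In this assay compound 4 is therefore expected to show only a small step, a 1.1-fold higher number from compound 2 to compound 4 (0.04 log units; within the scatter), not beyond the scatter. Compound 4 is estimated at 7000 nM, with a range from 3500 nM to 14000 nM.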

Compound 4, half-maximal inhibitory concentration: 9330 nM
Compound 4: the middle estimate sits 1.3-fold (0.12 log units) below what was measured; low and high end bracket the measured number.
By their numbers in this assay, from the lowest: compounds 2, 4, 3 and 1 (each within the scatter of the next, the first and the last beyond it).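

In this assay, among these compounds, the exchange of cyclohexyl for cyclopentyl on a double-bonded chain carbon bound to a double-bonded chain carbon is a 1.4-fold higher number from compound 2 to compound 4 (0.16 log units; within the scatter) and gives the first direct reading of one non-aromatic ring against another at this position. Among the compounds shown here, the earlier step at this position compared only two aromatic groups, whereas this one shows that, with the rest of compound 2 unchanged, a five-membered ring of carbon only and a six-membered one cannot be told apart here. No evidence is available on what lies behind this result.

The compounds shown leave open whether a ring carrying an amine, or a carboxylic acid at the end of the chain, would move the number beyond the scatter. They also give no reading for a longer chain between the double bond and the terminal ring, nor for an open-chain group such as tert-butyl in place of that ring.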